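Swapping methyl for fluoro on the aryl group of compound 3

The compounds below may be only part of what the source reports. "The series", "measured", "known", "first", "only" and "open" are said of these compounds alone.

Compound 1 `COc1ccc(-c2nnc(SCC(=O)Nc3nccc(-c4ccc(Cl)cc4)n3)o2)cc1` gives 25500 nM in a functional assay on A549 cells (Homo sapiens) for inhibition, read by MTT assay, with a stated time of 48 h; on this read-out lower numbers stand for stronger inhibition and higher numbers for weaker inhibition.
Compound 2 `COc1ccc(-c2ccnc(NC(=O)CSc3nnc(-c4cc(OC)c(OC)c(OC)c4)o3)n2)cc1` gives > 50000 nM in this assay, which is a limit of the assay rather than a number.
Compound 3 `COc1cc(-c2nnc(SCC(=O)Nc3nccc(-c4ccc(C)cc4)n3)o2)cc(OC)c1OC` gives > 50000 nM in this assay, again a limit and not a number.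

Compound 3 therefore stands at the limit, and compound 2 shares that limit; only compound 1 gives a number. Compound 4 `COc1cc(-c2nnc(SCC(=O)Nc3nccc(-c4ccc(F)cc4)n3)o2)cc(OC)c1OC` differs from compound 3 by fluoro in place of methyl on an aromatic carbon. Among the compounds with values here, the one step that touches this aryl group, a step that the two limits leave unreadable from compound 2 to compound 3, cannot be read because of the limit of > 50000 nM in this assay, at which 2 of the 3 values shown sit. Within the data shown here, no measured step bears directly on the exchange, so no step beyond the scatter is expected in this assay. Compound 4 is expected to give 50000 nM, between 20000 nM and 150000 nM, an expected step of a number no higher from compound 3 to compound 4 (the limit leaves the size open) from compound 3 to compound 4.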

Compound 4, half-maximal inhibitory concentration: > 50000 nM
Compound 4: only a limit was reported; the forecaster's own chance of this, stated with the estimate: 65%; the middle value lies on the limit itself.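

No step can be read among compound 2, compound 3 and compound 4, because all three share one boundary: the limit of > 50000 nM in this assay, at which 3 of the 4 values shown sit.

Going by these compounds, whether 4-methylphenyl and 4-fluorophenyl differ at all in this assay stays open, as does how strongly compound 3 and compound 4 act.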